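The source may report more compounds than this note shows. Statements on the series, on what has been measured and on what is new or still open speak of the compounds shown alone.

Values in a functional assay on NIH3T3 cells (Mus musculus); a lower number here means that less compound is needed, a higher number that more compound is needed for the effect:
- Compound 1 `Cn1cncc1C(OCc1ccc(C#N)cc1C#Cc1ccc(-c2ccccc2)cc1)c1ccc(C#N)cc1`: > 0.1 nM
- Compound 2 `Cn1cncc1C(OCc1ccc(C#N)cc1C#CCCCCO)c1ccc(C#N)cc1`: 20.9 nM
- Compound 3 `Cn1cncc1C(OCc1ccc(C#N)cc1C#Cc1ccccc1)c1ccc(C#N)cc1`: 0.1 nM

The reading of compound 1 is a limit of the assay, not a number. Of the two actual numbers, compound 3 holds the lower, and compound 2 holds the higher. Steps starting from compound 1 therefore have no readable size.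

Compound 4 `Cn1cncc1C(OCc1ccc(C#N)cc1C#CC(C)(C)C)c1ccc(C#N)cc1` has not yet been measured. It carries tert-butyl in place of phenyl on a triple-bonded carbon.

Among the measured compounds shown here, the one readable step that bears on this is a 210-fold lower number from compound 2 to compound 3 (2.32 log units; beyond the scatter), where phenyl enters in place of 4-hydroxybutyl. Read backwards, it suggests that losing the phenyl may raise the number. However, tert-butyl is not 4-hydroxybutyl, and this is a single step, so the full size need not carry over.

A rise in this assay is expected, estimated as a 20-fold higher number from compound 3 to compound 4 (1.30 log units; beyond the scatter). Compound 4 is expected at 2 nM, with an estimated range from 0.2 nM to 20 nM.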

Compound 4, half-maximal effective concentration: 76.9 nM
Compound 4: middle estimate off by 38-fold (1.58 log units), on the low side; the measured number lies above the stated range.
By their numbers in this assay, from the lowest: compound 3; then compound 2; then compound 4.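

In this assay, replacing phenyl with tert-butyl on the triple-bonded carbon gives a 770-fold higher number from compound 3 to compound 4 (2.89 log units; beyond the scatter), so the large loss seen with 4-hydroxybutyl is not peculiar to that chain. The two groups without a ring also differ from each other, with a 3.7-fold higher number from compound 2 to compound 4 (0.57 log units; beyond the scatter), but this step is modest against the one away from phenyl, and among the readable values only compound 3 has a low number. Compound 1 gives a limit and not a number, so the steps from it cannot be read: the limit of > 0.1 nM in this assay, at which 1 of the 4 values shown sits.

Whether the low number of compound 3 needs an aromatic ring at this carbon remains open, since cyclohexyl, a saturated ring of the same size, does not appear among these compounds. Nor do the compounds show how a pyridyl ring or a substituted phenyl, such as 4-methoxyphenyl, would compare with phenyl.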